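This account rests on a few compounds, and the source may have more. Where it says the series, first, only, none or still open, it means among the compounds named here.

Compound 1 `Cc1cccc(/C=N/Nc2ncc3c(n2)n(C2CCCC2)c(=O)c(=O)n3C)c1` gives 53600 nM in a functional assay on PC-3 cells (Homo sapiens) for antiproliferative activity, read by MTT assay; a lower number here means a stronger inhibitor, a higher number a weaker inhibitor; compound 2 `Cn1c(=O)c(=O)n(C2CCCC2)c2nc(N/N=C/c3ccc(Cl)cc3)ncc21` gives 8420 nM; compound 3 `COc1cccc(/C=N/Nc2ncc3c(n2)n(C2CCCC2)c(=O)c(=O)n3C)c1` gives 20700 nM.

Compound 2 thus stands lowest of the three numbers measured, with compound 3 nearest and compound 1 furthest; the steps of a 6.4-fold lower number from compound 1 to compound 2 (0.80 log units; beyond the scatter) and a 2.5-fold higher number from compound 2 to compound 3 (0.39 log units; beyond the scatter) are both beyond the scatter, so compound 2 is the strongest of the three in this assay .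

Compound 4 `Cn1c(=O)c(=O)n(C2CCCC2)c2nc(N/N=C/c3ccc(C(F)(F)F)cc3)ncc21` differs from compound 2 in one place: trifluoromethyl in place of chloro on an aromatic carbon. For the measured compounds named here, none of the measured steps exchanges one group for another at this same position. The step of a 2.6-fold lower number from compound 1 to compound 3 (0.41 log units; beyond the scatter) swaps groups on the ring but at a different position, and the step of a 6.4-fold lower number from compound 1 to compound 2 (0.80 log units; beyond the scatter) changes both group and position, so neither bears directly on a change from chloro to trifluoromethyl. The measured series shows that changes on this ring move the number by modest amounts, and a similarly modest step, or none beyond the scatter, is therefore expected in this assay . Compound 4 is estimated at 7000 nM, within the range 2500 nM to 20000 nM, a step of a 1.2-fold lower number from compound 2 to compound 4 (0.08 log units; within the scatter).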

Compound 4, half-maximal inhibitory concentration: 23600 nM
For compound 4 the middle estimate is 3.4-fold (0.53 log units) below the measured one; the whole stated range lies below it.
By their numbers in this assay, from the lowest: compound 2; then compounds 3 and 4 (each within the scatter of the next); then compound 1.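

In this assay, the position para to a large group responds to an exchange of one group for another: trifluoromethyl in place of chloro gives a 2.8-fold higher number from compound 2 to compound 4 (0.45 log units; beyond the scatter), the only step shown that changes the group while keeping the position, and here chloro gives the lower number. The 4-(trifluoromethyl)phenyl group still improves on 3-methylphenyl, with a 2.3-fold lower number from compound 1 to compound 4 (0.36 log units; beyond the scatter), but cannot be told apart from 3-methoxyphenyl, with a 1.1-fold higher number from compound 3 to compound 4 (0.06 log units; within the scatter). Nothing available explains these differences.

With only chloro and trifluoromethyl shown at this position, it remains open how an amine, a carboxylic acid or a nitrile would fare there. As far as these compounds go, it is also open whether chloro would keep its advantage over trifluoromethyl on another carbon of the ring.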